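Notes on the fluorophenyl oximes: adding a second fluorine

A few compounds are considered here, and "the series" means these few. Any claim that something is new, unique, unknown or untested is made for them only; others in the source may bear on it.

Three compounds of the shared core have numbers in a functional assay on the whole organism (strain Swiss albino) for inhibition, with Mus musculus as the target, in the writhing test, with a stated time of 30 min, at a dose of 20 mg/kg by the oral route; on this read-out higher numbers stand for a stronger effect at the one dose given and lower numbers for a weaker effect. Compound 1 `Cc1c(C=O)cc(-c2ccc(S(C)(=O)=O)cc2)n1-c1ccc(F)c(F)c1`, the aldehyde carrying a 3,4-difluorophenyl group, gives 52%. Compound 2 `Cc1c(/C=N\O)cc(-c2ccc(S(C)(=O)=O)cc2)n1-c1ccc(F)cc1`, the oxime with a 4-fluorophenyl group, gives 41%. Compound 3 `Cc1c(/C=N\O)cc(-c2ccc(S(C)(=O)=O)cc2)n1-c1cccc(F)c1`, the oxime with a 3-fluorophenyl group, gives 42%. On these three numbers compound 3 sits second highest, yet its gap to compound 2, shown by a number 1 percentage points higher from compound 2 to compound 3 (within the scatter), is within the scatter, and its gap to compound 1 is within the scatter as well. Among the compounds with values here, the single measured step, moving the fluoro to another position of the phenyl, changes nothing beyond the scatter.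

Compound 4 `Cc1c(/C=N\O)cc(-c2ccc(S(C)(=O)=O)cc2)n1-c1ccc(F)c(F)c1` differs from compound 3 by fluoro in place of hydrogen on an aromatic carbon, that is 3-fluorophenyl to 3,4-difluorophenyl, with the oxime kept. Within the data shown here, no measured pair adds a second fluoro to this ring; compound 1 carries the same 3,4-difluorophenyl group but differs from compound 3 in the aldehyde too, so its number is not a step. Among the measured compounds shown here, the only step touching fluoro on this ring, a number 1 percentage points higher from compound 2 to compound 3 (within the scatter), is within the scatter, so in this assay no change beyond the scatter is expected. The step of a number 3 percentage points higher from compound 3 to compound 4 (within the scatter) is expected to be small. Compound 4 is estimated at 45%, within 32% to 58%.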

Compound 4, a percentage reported as inhibition, in the whole organism at one dose (the size of the read-out at that dose, not a potency): 27%
Compound 4: middle estimate off by 18 percentage points, on the high side; the measured number lies below the stated range.
By their numbers in this assay, from the lowest: compound 4; then compounds 2, 3 and 1 (each within the scatter of the next, the first and the last beyond it).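

In this assay, within the data shown here, the second fluoro is the first change on this ring to go beyond the scatter, with the oxime kept: the step reads a number 15 percentage points lower from compound 3 to compound 4 (beyond the scatter) and, against the other monofluorophenyl oxime, a number 14 percentage points lower from compound 2 to compound 4 (beyond the scatter) while moving the single fluoro gave only a number 1 percentage points higher from compound 2 to compound 3 (within the scatter) as the earlier step. Among these compounds, with the 3,4-difluorophenyl group held constant, the group on the aromatic carbon of the core also matters, as the oxime in place of the aldehyde gives a number 25 percentage points lower from compound 1 to compound 4 (beyond the scatter) and no earlier pair isolated that change. Nothing available here accounts for either effect.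

The compounds shown leave open whether the lower number belongs to fluoro itself or would also appear with chloro or methoxy in its place on the 3-fluorophenyl ring. They also leave open whether a second fluoro lowers the number in the aldehyde as it does in the oxime, and how a carboxylic acid in place of the oxime would read at this dose.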